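Nitro in place of hydrogen on the benzoyl ring

The source may hold more compounds than are shown below. What is called first, only, known or untested is meant among the compounds shown, and "the series" means these compounds.

Compound 3 `O=C(COc1ccc2c(=O)ccoc2c1)Nc1cccc(NC(=O)c2ccccc2)c1` gives 120 nM in an assay on isolated protein for inhibition of Rho-associated protein kinase 1 (Homo sapiens), read by scintillation counting, radiometric assay and 33P incorporation, with a stated time of 40 min, in the presence of a further agent that is not named here (a lower number here means a stronger inhibitor, a higher number a weaker inhibitor), the lowest of the two numbers shown. Compound 1 `COc1cc(OCC(=O)Nc2cccc(NC(=O)c3ccc(N(C)C)cc3)c2)ccc1C=O` gives 3740 nM in this assay. Compound 2 `CN(C)c1ccc(C(=O)Nc2cccc(NC(=O)COc3ccc4occc(=O)c4c3)c2)cc1` gives only > 10000 nM, which is a limit of the assay, (the limit of > 10000 nM in this assay, at which 1 of the 3 values shown sits). Going by the values given here, the single measured step, an at least 2.6-fold higher number from compound 1 to compound 2 (0.42 log units; beyond the scatter), alters the aryloxy end and not the benzoyl ring, so no measured step bears on the change from compound 3 to compound 4 `O=C(COc1ccc2c(=O)ccoc2c1)Nc1cccc(NC(=O)c2ccc([N+](=O)[O-])cc2)c1`: nitro in place of hydrogen on an aromatic carbon. Among the compounds with values here, compounds 2 and 3 differ on that same ring, though by another group, and their values show only that a substituted benzoyl ring went with a limit there. A modest weakening is therefore expected, a 2.9-fold higher number from compound 3 to compound 4 (0.46 log units; beyond the scatter). Compound 4 is expected at 350 nM, within 100 nM to 1500 nM.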

Compound 4, half-maximal inhibitory concentration: 67 nM
Estimate against measurement, compound 4: 5.2-fold (0.72 log units) above, and the stated range ends above it.
By their numbers in this assay, from the lowest: compounds 4 and 3 (each within the scatter of the next); then compound 1. At a limit, above all of these: compound 2.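

Nitro in place of hydrogen on an aromatic carbon, para to a large group, gives a 1.8-fold lower number from compound 3 to compound 4 (0.25 log units; within the scatter) in this assay. Going by these compounds alone, this is the first single-place step on the benzoyl ring, and it shows that this position takes the three added heavy atoms of nitro with no difference beyond the scatter. Nothing shown gives a reason for this result.

On these data alone, it remains open whether an amine or a carboxylic acid in the same place on the benzoyl ring would match nitro. Also open, as far as these compounds go, is whether nitro gives a similar value at another position on that ring.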